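The source may hold more compounds than are shown below. What is called first, only, known or untested is meant among the compounds shown, and "the series" means these compounds.

Compound 1 `Nc1ccccc1NC(=O)c1ccc(CNCc2nc(-c3ccc(F)cc3)no2)cc1` gives 3510 nM in a functional assay on HCT-116 cells (Homo sapiens) for inhibition, read by MTT assay, with a stated time of 72 h; a higher number here means a weaker inhibitor, a lower number a stronger inhibitor. Compound 2 `Nc1ccccc1NC(=O)c1ccc(CNCc2nc(-c3cccs3)no2)cc1` differs from compound 1 by thiophen-2-yl in place of 4-fluorophenyl on an aromatic carbon, and in this assay compound 2 gives 27200 nM, which is a step of a 7.7-fold higher number from compound 1 to compound 2 (0.89 log units; beyond the scatter). Compound 3 `O=C(NO)c1ccc(CNCc2nc(-c3ccc(F)cc3)no2)cc1` differs from compound 1 by hydroxy in place of 2-aminophenyl on an amide-type nitrogen, and in this assay compound 3 gives 17800 nM, a step of a 5.1-fold higher number from compound 1 to compound 3 (0.71 log units; beyond the scatter). Among the measured compounds shown here, compound 4 `O=C(NO)c1ccc(CNCc2nc(-c3cccs3)no2)cc1` has not yet been measured; it differs from compound 3 by thiophen-2-yl in place of 4-fluorophenyl on an aromatic carbon, the same change as the one made from compound 1 to compound 2, now on the core of compound 3. Compound 4 is expected to be weaker in this assay by roughly a 5.6-fold higher number from compound 3 to compound 4 (0.75 log units; beyond the scatter), an expectation that rests on one earlier example only, because a 7.7-fold higher number from compound 1 to compound 2 (0.89 log units; beyond the scatter) was seen on the core of compound 1. The estimate for compound 4 is 100000 nM, likely between 30000 nM and 300000 nM.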

Compound 4, half-maximal inhibitory concentration: > 100000 nM
Compound 4: no number, only a limit; the forecaster's own chance of this, stated with the estimate: 25%; the middle value lies on the limit itself.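

In this assay compound 4 gives > 100000 nM, which is a limit of the assay and not a number. As far as these compounds go, putting thiophen-2-yl in place of 4-fluorophenyl raises the number on the second core too, with an at least 5.6-fold higher number from compound 3 to compound 4 (0.74 log units; beyond the scatter), so the direction of this change carries over, though its size on this core stays unknown: the same change on two cores in this assay, a 7.7-fold higher number (0.89 log units; beyond the scatter) from compound 1 to compound 2 and an at least 5.6-fold higher number (0.74 log units; beyond the scatter) from compound 3 to compound 4; the limit leaves it open whether they differ. Hydroxy in place of 2-aminophenyl also keeps its direction on the thiophen-2-yl core, with an at least 3.6-fold higher number from compound 2 to compound 4 (0.56 log units; beyond the scatter), and again only the direction can be compared: the same change on two cores in this assay, a 5.1-fold higher number (0.71 log units; beyond the scatter) from compound 1 to compound 3 and an at least 3.6-fold higher number (0.56 log units; beyond the scatter) from compound 2 to compound 4; the limit leaves it open whether they differ.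

These four compounds test each change on just two cores. From the compounds shown here alone, it stays open whether an unsubstituted phenyl or a pyridin-3-yl in the same place would follow this direction.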